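Ring-carbon substituent on the shared core: step toward compound 4

The source may hold more compounds than are shown below. What is called first, only, known or untested is meant among the compounds shown, and "the series" means these compounds.

Measured compounds in a functional assay on DLD-1 cells (Homo sapiens) for antiproliferative activity, read by CellTiter-Glo, with a stated time of 72 h; a lower number here means a stronger inhibitor, a higher number a weaker inhibitor:
compound 1 `Cc1cc(C)c(S(=O)(=O)N2CCC(N3CCC(C)CC3)CC2)c(C)c1` gives 0.03 nM
compound 2 `Cc1cc(C)c(S(=O)(=O)N2CCC(N3CCC(c4ccccc4)CC3)CC2)c(C)c1` gives 865 nM
compound 3 `Cc1cc(C)c(S(=O)(=O)N2CCC(N3CCC(C(C)C)CC3)CC2)c(C)c1` gives 0.3 nM

Compound 3 stands second highest of the three numbers in this assay. Its nearest neighbour is compound 1, a step of a 10-fold higher number from compound 1 to compound 3 (1.00 log units; beyond the scatter). The furthest is compound 2, a step of a 2900-fold lower number from compound 2 to compound 3 (3.46 log units; beyond the scatter), so the phenyl analogue sits far weaker than either alkyl analogue.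

Compound 4 `C#CCCC(=O)CC1CCN(C2CCN(S(=O)(=O)c3c(C)cc(C)cc3C)CC2)CC1` differs from compound 3 in one place: ((but-3-yn-1-yl)carbonyl)methyl in place of isopropyl on a saturated ring carbon. The group that enters is larger than the isopropyl it replaces but is not a ring, so the step sits between two measured precedents. Enlarging methyl to isopropyl cost a 10-fold higher number from compound 1 to compound 3 (1.00 log units; beyond the scatter), enlarging to phenyl cost a 29000-fold higher number from compound 1 to compound 2 (4.46 log units; beyond the scatter). A further growth of the group at this ring carbon is therefore expected to raise the number in this assay by a large margin, though with wide uncertainty, since no chain of this kind has been measured.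

For compound 4 the estimated step is a 100-fold higher number from compound 3 to compound 4 (2.00 log units; beyond the scatter). Compound 4 is expected to give about 30 nM, within 1 nM to 1000 nM.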

Compound 4, half-maximal inhibitory concentration: 3 nM
Beside the measured number, compound 4's estimate is 10-fold (1.00 log units) above it, and the stated range covers the measured number.
By their numbers in this assay, from the lowest: compound 1; then compound 3; then compound 4; then compound 2.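

In this assay a long open chain at this ring carbon is far better accepted than phenyl: ((but-3-yn-1-yl)carbonyl)methyl in place of isopropyl gives a 10-fold higher number from compound 3 to compound 4 (1.00 log units; beyond the scatter) and only a modest loss, while the same chain in place of phenyl gives a 290-fold lower number from compound 2 to compound 4 (2.46 log units; beyond the scatter) as a large gain. Growth of the group therefore does not by itself set the number here, and a chain bearing a carbonyl and a triple bond stays in the low range of the series, though methyl remains clearly preferred, with a 100-fold higher number from compound 1 to compound 4 (2.00 log units; beyond the scatter) as a large step. No measurement shown accounts for the gap between this chain and phenyl.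

The compounds shown do not separate the contribution of the carbonyl from that of the triple bond. As far as these compounds go, an unbranched hexyl chain, a cyclohexyl ring, or an amine or carboxylic acid at the chain end also remain open.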